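The compounds below may be only part of what the source reports. "The series", "measured", "known", "first", "only" and "open" are said of these compounds alone.

In an ADME assay on HEK293 cells (Homo sapiens) for cytotoxicity, read by CCK-8 assay, with a stated time of 4 days (a lower number here means a stronger inhibitor, a higher number a weaker inhibitor), two compounds have been measured. Compound 1 `Oc1ccc(-c2cc(-c3cccc(O)c3)nc(-c3ccccc3O)c2)cc1` gives 7420 nM, while compound 2 `Oc1ccc(-c2cc(-c3cccc(O)c3)cc(-c3cccc(O)c3)n2)cc1` gives 1560 nM, the lowest of the two numbers; the gap between them is well beyond the scatter of the assay. Compound 3 `Oc1ccc(-c2cc(-c3ccc(O)cc3)nc(-c3cccc(O)c3)c2)cc1` has not yet been measured in this assay. It is built from the same atoms as compound 2, joined differently: 4-hydroxyphenyl in place of 3-hydroxyphenyl on an aromatic carbon, on the carbon opposite the ring nitrogen. Within the data shown here, no pair of measured compounds shows what such a change does, so the size of the step in this assay is not known from the data. Compound 3 is expected to stay close to compound 2, with a step of a 1.3-fold higher number from compound 2 to compound 3 (0.11 log units; within the scatter) that would not go beyond the scatter in either direction. Compound 3 is therefore estimated at 2000 nM in this assay, with a range from 700 nM to 6000 nM.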

Compound 3, half-maximal inhibitory concentration: 840 nM
For compound 3 the middle estimate is 2.4-fold (0.38 log units) above the measured one, and the stated range covers the measured number.
By their numbers in this assay, from the lowest: compounds 3 and 2 (each within the scatter of the next); then compound 1.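

In this assay, the step of a 1.9-fold lower number from compound 2 to compound 3 (0.27 log units; within the scatter) stays within the scatter, so on the carbon opposite the ring nitrogen, 4-hydroxyphenyl and 3-hydroxyphenyl cannot be told apart. Placing 4-hydroxyphenyl on an aromatic carbon in place of 2-hydroxyphenyl gives a clearer result, with an 8.8-fold lower number from compound 1 to compound 3 (0.95 log units; beyond the scatter) lying beyond the scatter, so compound 1 stands apart from compound 3 in a way that compound 2 does not. Nothing available explains either step. The compounds shown leave open what an aminophenyl, a methoxyphenyl or a benzoic acid group would give on the carbon opposite the ring nitrogen. They also leave open whether the gap between compound 1 and compound 3 would persist with a plain phenyl ring in place of 2-hydroxyphenyl.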